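A few compounds are considered here, and "the series" means these few. Any claim that something is new, unique, unknown or untested is made for them only; others in the source may bear on it.

Measured so far in an ADME assay on MDBK cells (Bos taurus) for cytotoxicity; a higher number here means that more compound is tolerated, a lower number that less compound is tolerated:
Compound 1 `Fc1cccc(F)c1Cn1c(-c2c(F)cccc2F)nc2ccncc21` gives 99000 nM.
Compound 2 `N#Cc1ccccc1Cn1ccc2nc(-c3ccccc3)nc-2c1` gives > 100000 nM, a limit of the assay rather than a number.
Compound 3 `FC(F)(F)c1ccccc1Cn1ccc2nc(-c3ccccc3)nc-2c1` gives > 100000 nM, likewise a limit of the assay.

Compound 2 thus stands at the limit of > 100000 nM in this assay, at which 2 of the 3 values shown sit; the step that the two limits leave unreadable from compound 2 to compound 3 cannot be read. Compound 4 `c1ccc(-c2nc3ccn(Cc4ccncc4)cc-3n2)cc1` is a new substitution on the core shared with compound 2: pyridin-4-yl in place of 2-cyanophenyl on a saturated chain carbon bound to an aromatic nitrogen. For the measured compounds named here, no measured step bears on this change, and the two limits give no size to go by. Compound 1 shows the series tolerated at the upper end of the measured window. For compound 4 the expectation is a step of a number no higher from compound 2 to compound 4 (the limit leaves the size open), that is, no change beyond the scatter. Compound 4 is estimated at 100000 nM, between 50000 nM and 200000 nM.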

Compound 4, half-maximal cytotoxic concentration: > 100000 nM
Compound 4 gave a limit, no number; the forecaster's own chance of this, stated with the estimate: 60%; the middle value sits exactly at the limit.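

Compound 2 and compound 4 both give limits rather than numbers in this assay, and no step between them can be read: the limit of > 100000 nM in this assay, at which 3 of the 4 values shown sit.

The compounds shown leave open whether pyridin-4-yl in place of 2-cyanophenyl changes tolerance at all.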